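From pyrrolidin-1-yl to 2-(methoxycarbonyl)pyrrolidin-1-yl

A few compounds are considered here, and "the series" means these few. Any claim that something is new, unique, unknown or untested is made for them only; others in the source may bear on it.

Within the data shown here, in an in vivo functional assay on the whole organism for inhibition, with Rattus norvegicus as the target (a higher number here means that more compound is needed for the effect, a lower number that less compound is needed), compound 1 (`CCCCc1nc(C)c(CC(=O)N(C)C)c(=O)n1Cc1ccc(-c2ccccc2-c2nnn[nH]2)cc1`) gives 0.018 mg/kg, and compound 2 (`CCCCc1nc(C)c(CC(=O)N2CCCC2)c(=O)n1Cc1ccc(-c2ccccc2-c2nnn[nH]2)cc1`) gives 0.056 mg/kg, the higher of the two numbers so far. Compound 3 (`CCCCc1nc(C)c(CC(=O)N2CCC[C@H]2C(=O)OC)c(=O)n1Cc1ccc(-c2ccccc2-c2nnn[nH]2)cc1`) carries methoxycarbonyl in place of hydrogen on a saturated ring carbon, next to the ring nitrogen: methoxycarbonyl in place of hydrogen on a saturated ring carbon. Among the measured compounds shown here, one measured step bears on this, a 3.1-fold higher number from compound 1 to compound 2 (0.49 log units; beyond the scatter), a modest change at the same amide. For the measured compounds named here, it offers only a rough scale, as no measured compound carries methoxycarbonyl. The expected change is a 2.1-fold higher number from compound 2 to compound 3 (0.33 log units; beyond the scatter), a modest step toward a higher number. For compound 3 the estimate is 0.12 mg/kg, with an expected range of 0.03 mg/kg to 0.5 mg/kg.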

Compound 3, dose for half-maximal effect: 0.043 mg/kg
Estimate against measurement, compound 3: 2.8-fold (0.45 log units) above; measured number inside the range.
By their numbers in this assay, from the lowest: compound 1; then compounds 3 and 2 (each within the scatter of the next).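

In this assay, methoxycarbonyl in place of hydrogen on a saturated ring carbon, next to the ring nitrogen, leaves the number unchanged within the scatter (a 1.3-fold lower number from compound 2 to compound 3 (0.11 log units; within the scatter)). The difference from the dimethylamino amide persists (a 2.4-fold higher number from compound 1 to compound 3 (0.38 log units; beyond the scatter)), so adding this group to the pyrrolidine amide does not close that gap. No measured property accounts for either step.

Open, as far as these compounds go, is what a carboxylic acid or hydroxymethyl on the same ring carbon would give. From the compounds shown here alone, the opposite configuration at that carbon is also open.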